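This account rests on a few compounds, and the source may have more. Where it says the series, first, only, none or still open, it means among the compounds named here.

Half-lives measured so far:
compound 1 `CC(C)C(Nc1nnc[nH]1)c1ccc(-c2ccc3cccc(F)c3c2)[nH]c1=O` gives 1.29 h
compound 2 `CC(C)C(c1ccc(-c2ccc3cccc(F)c3c2)[nH]c1=O)N1CCN/C1=N\C#N` gives 0.327 h
compound 3 `CC(C)C(c1noc(=O)[nH]1)c1ccc(-c2ccc3cccc(F)c3c2)[nH]c1=O` gives > 3 h

All three values come from an ADME assay on microsomes from liver (Rattus norvegicus) for metabolic stability; on this read-out lower numbers stand for a shorter-lived compound and higher numbers for a longer-lived compound. The entry for compound 3 is a limit of the assay and not a number. It is the highest entry of the set: an at least 2.3-fold higher number from compound 1 to compound 3 (0.36 log units; beyond the scatter) and an at least 9.1-fold higher number from compound 2 to compound 3 (0.96 log units; beyond the scatter) both lie beyond the scatter.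

The next structure is compound 4 `CC(C)C(c1ccc(-c2ccc3cccc(F)c3c2)[nH]c1=O)N1CCNC1=O` and the difference is a group of 6 heavy atoms (3 carbon, 2 nitrogen, 1 oxygen; one five-membered non-aromatic ring with 2 hetero atoms) in place of a group of 6 heavy atoms (2 carbon, 2 nitrogen, 2 oxygen; one five-membered aromatic ring with 3 hetero atoms), on a saturated chain carbon bound to an aromatic carbon and a saturated chain carbon with the 2-oxoimidazolidin-1-yl group entering on the same saturated chain carbon.

Going by the values given here, the most relevant steps involve compound 2, the only measured compound with a five-membered non-aromatic ring at this place. Moving from an aromatic ring to that non-aromatic ring gave a 3.9-fold lower number from compound 1 to compound 2 (0.60 log units; beyond the scatter) and moving back to an aromatic ring gave an at least 9.1-fold higher number from compound 2 to compound 3 (0.96 log units; beyond the scatter) in the opposite direction. This pattern rests on compound 2 alone, and the two aromatic rings also differ from each other, as an at least 2.3-fold higher number from compound 1 to compound 3 (0.36 log units; beyond the scatter) shows.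

A drop of similar size is therefore expected, beyond the scatter, and the expected step is an at least 4.2-fold lower number from compound 3 to compound 4 (0.63 log units; beyond the scatter) in this assay on this basis. The estimated value for compound 4 is 0.7 h with an expected range from 0.25 h to 2 h in this read-out.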

Compound 4, half-life: 0.283 h
The estimate for compound 4 lay 2.5-fold (0.39 log units) above the measured number; the measured number falls inside the stated range.
By their numbers in this assay, from the lowest: compounds 4 and 2 (each within the scatter of the next); then compound 1. At a limit, above all of these: compound 3.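

With the 2-oxoimidazolidin-1-yl group on this saturated chain carbon, this assay now holds two five-membered non-aromatic rings at this place, and they do not separate (a 1.2-fold lower number from compound 2 to compound 4 (0.06 log units; within the scatter)), so the low numbers no longer rest on compound 2 alone. Both aromatic groups stand clear of compound 4, by a modest step from the (4H-1,2,4-triazol-3-yl)amino group (a 4.6-fold lower number from compound 1 to compound 4 (0.66 log units; beyond the scatter)) and by a large one from the five-membered aromatic ring with two oxygen atoms in its group (an at least 10-fold lower number from compound 3 to compound 4 (1.02 log units; beyond the scatter)), so among these four compounds the aromatic rings go with the longer half-lives and none goes against this. The entry for compound 3 is a limit of the assay: the limit of > 3 h in this assay, at which 1 of the 4 values shown sits.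

On these data alone, whether the aromatic ring as such or some other difference between these groups tracks the half-life stays open, with only four compounds at this place. Where a tetrazole, a carboxylic acid or an open-chain urea on the same saturated chain carbon would fall in this order also stays open.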